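Working notes: pyridine substituent change toward compound 3

The source may hold more compounds than are shown below. What is called first, only, known or untested is meant among the compounds shown, and "the series" means these compounds.

Among the compounds with values here, in an in vitro assay on HEK385-7 cells for displacement of a labelled ligand from prostaglandin D2 receptor 2 (Homo sapiens) (on this read-out lower numbers stand for stronger inhibition and higher numbers for weaker inhibition), compound 1 `O=C(O)Cc1sc(C(c2ccc(F)cc2)c2ccc(F)cc2)nc1-c1ccccc1` gives 16 nM, and compound 2 `O=C(O)Cc1sc(C(c2ccc(F)cc2)c2ccc(F)cc2)nc1-c1cc(F)nc(F)c1` gives 5.4 nM, the lowest of the two numbers measured so far. Within the data shown here, the only step known, a 3.0-fold lower number from compound 1 to compound 2 (0.47 log units; beyond the scatter), is the one that bears on the next change. Compound 3 `CN(C)c1cc(-c2nc(C(c3ccc(F)cc3)c3ccc(F)cc3)sc2CC(=O)O)ccn1` carries 2-(dimethylamino)pyridin-4-yl in place of 2,6-difluoropyridin-4-yl on an aromatic carbon. Among the measured compounds shown here, no measured pair swaps substituents on the same pyridine, so the direction is open; a number near that of compound 2 is expected. The estimate for compound 3 is 9 nM, with a range from 3 nM to 30 nM. That estimate means a 1.7-fold higher number from compound 2 to compound 3 (0.22 log units; within the scatter), expected to stay within the scatter.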

Compound 3, half-maximal inhibitory concentration: 380 nM
Beside the measured number, compound 3's estimate is 42-fold (1.63 log units) below it; the whole stated range lies below it.
By their numbers in this assay, from the lowest: compound 2; then compound 1; then compound 3.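

At this aromatic carbon, the pyridine's substituents matter far more than the earlier step from phenyl showed: in this assay, 2-(dimethylamino)pyridin-4-yl in place of 2,6-difluoropyridin-4-yl gives a 70-fold higher number from compound 2 to compound 3 (1.85 log units; beyond the scatter). The same group also falls behind plain phenyl, with a 24-fold higher number from compound 1 to compound 3 (1.38 log units; beyond the scatter), so a pyridine ring alone does not secure the lower number of compound 2. Nothing available explains this loss.

Still open, as far as these compounds go, is whether a methoxy group or a primary amine on the pyridine would keep the number near that of compound 2. The compounds shown also do not separate the effect of removing the fluorines from that of adding dimethylamino.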